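Swapping the amine at the end of the sulfonyl chain

This account rests on a few compounds, and the source may have more. Where it says the series, first, only, none or still open, it means among the compounds named here.

Compound 1, with the structure `CN1CCN(CCCS(=O)(=O)c2ccc3nc(NC(=O)NC(=O)c4ccccc4Cl)sc3c2)CC1`, is the more polar of the two measured compounds in a physicochemical assay for lipophilicity (a lower number here means a more polar compound, a higher number a more lipophilic compound), where compound 1 gives 1.8. Within the data shown here, the only other measured compound is compound 2, with the structure `CN1CCN(CCCS(=O)(=O)c2ccc3nc(NC(=O)NC(=O)c4cc(-n5cccc5)ccc4Cl)sc3c2)CC1`; in this assay compound 2 gives 2.6. Among the measured compounds shown here, the single measured step, a number 0.80 log units higher from compound 1 to compound 2 (beyond the scatter), sits on the aromatic ring and leaves the chain untouched.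

Compound 3 has the structure `CCN(CC)CCCS(=O)(=O)c1ccc2nc(NC(=O)NC(=O)c3ccccc3Cl)sc2c1`. It differs from compound 1 as follows: diethylamino in place of 4-methylpiperazin-1-yl on a saturated chain carbon, three bonds along the chain from a sulfonyl sulfur. For the measured compounds named here, no measured step concerns this chain end, so the step from compound 1 to compound 2 does not bear on it, and the expectation must rest on the change itself, which is therefore uncertain. A small rise in this assay is expected, about a number 0.30 log units higher from compound 1 to compound 3 (within the scatter), but one that may well fall within the scatter.

For compound 3 the estimated value in this assay is 2.1, with a likely range from 1.5 to 2.7.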

Compound 3, distribution coefficient: 1.7
The estimate for compound 3 lay 0.40 log units above the measured number; the range from low to high includes it.
By their numbers in this assay, from the lowest: compounds 3 and 1 (each within the scatter of the next); then compound 2.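

Replacing 4-methylpiperazin-1-yl with diethylamino on the saturated chain carbon gives a number 0.10 log units lower from compound 1 to compound 3 (within the scatter), so this assay cannot tell these two compounds apart, even though the swap removes the ring and one nitrogen and leaves 5 heavy atoms in place of 7. Among these compounds, this is the first measured look at the chain end, and the step here stands in contrast to the one on the aromatic ring, a number 0.80 log units higher from compound 1 to compound 2 (beyond the scatter), which remains the only step beyond the scatter. No other measurement shown here offers an explanation for this result.

The compounds shown leave open whether a morpholine ring or a primary amine at the end of the chain would also stay within the scatter of compound 1, and whether a carboxylic acid there, or a chain longer than the propyl chain, would shift the number. Also open is what diethylamino would do in compound 2, which carries 1H-pyrrol-1-yl: the two changes appear together in no compound shown.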